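A few compounds are considered here, and "the series" means these few. Any claim that something is new, unique, unknown or untested is made for them only; others in the source may bear on it.

In a functional assay on LNCaP cells (Homo sapiens) for antiproliferative activity, read by WST assay, with a stated time of 3 days (on this read-out higher numbers stand for weaker inhibition and lower numbers for stronger inhibition), compound 1 `C/C1=C/C=C/C(=O)O[C@H](CO)C/C(C)=C/COCC/C=C/C(=O)C1` gives 19300 nM, while compound 2 `COc1ccc(COC[C@H]2C/C(C)=C/COCC/C=C/C(=O)C/C(C)=C\C=C\C(=O)O2)cc1` gives 2850 nM, the lower of the two numbers, with a gap beyond the scatter. Compound 3 `C/C1=C/C=C/C(=O)O[C@@H](CO)C/C(C)=C/COCC/C=C/C(=O)C1` arises from compound 2 through (hydrogen in place of 4-methoxybenzyl on an oxygen on a saturated carbon), which turns (4-methoxybenzyl)oxy into hydroxy. Going by the values given here, no measured step shows this change directly. Compound 1 also carries hydroxymethyl and gives 19300 nM, so a move to weaker inhibition, beyond the scatter, is expected in this assay. The estimated change is a 4.6-fold higher number from compound 2 to compound 3 (0.66 log units; beyond the scatter). For compound 3 the expected value is 13000 nM, with an estimated range of 4500 nM to 35000 nM.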

Compound 3, half-maximal inhibitory concentration: > 30000 nM
Compound 3 ended at the assay's limit; the forecaster's own chance of this, stated with the estimate: 10%; middle value at least 2.3-fold (0.36 log units) from the limit.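

In this assay compound 3 gives > 30000 nM, which is a limit of the assay and not a number: the limit of > 30000 nM in this assay, at which 1 of the 3 values shown sits.
Replacing 4-methoxybenzyl with hydrogen on this oxygen gives a large loss of inhibition, with an at least 10-fold higher number from compound 2 to compound 3 (1.02 log units; beyond the scatter). The comparison of the two hydroxymethyl compounds gives only an at least 1.5-fold higher number from compound 1 to compound 3 (0.19 log units; that floor lies within the scatter), so no effect of the configuration at this stereocentre can be read: the fact that compounds 1 and 3 differ only in the configuration as drawn

The compounds shown leave open whether a plain benzyl or methyl on this oxygen, or an amine in place of the hydroxy, would match compound 2. They also leave open how a 4-methoxybenzyl compound with the opposite configuration would compare.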